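The source may report more compounds than this note shows. Statements on the series, on what has been measured and on what is new or still open speak of the compounds shown alone.

Measured compounds:

Compound 1, `O=C(Nc1cccc(-n2cc(-c3ccncc3)c(-c3ccc(Cl)c(O)c3)n2)c1)Nc1ccc(Cl)c(Cl)c1`, 679 nM
Compound 2, `COc1cc(-c2nn(-c3cccc(NC(=O)c4cccc(C(F)(F)F)c4)c3)cc2-c2ccncc2)ccc1Cl`, 555 nM
Compound 3, `O=C(Nc1cccc(-n2cc(-c3ccncc3)c(-c3ccc(Cl)c(O)c3)n2)c1)Nc1cc(C(F)(F)F)cc(C(F)(F)F)c1`, 344 nM

All three values come from a functional assay on HOP-92 cells (Homo sapiens) for inhibition, read by sulforhodamine B assay, with a stated time of 48 h; a higher number here means a weaker inhibitor of growth, a lower number a stronger inhibitor of growth. Compound 1 gives 679 nM, the highest of the three numbers, but its gap to compound 2 and its gap to compound 3 both lie within the usual scatter, so none of the three can be separated from the others on these data. For the measured compounds named here, no single-point steps between measured compounds are available, so no measured step sets a scale for what follows.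

Compound 4, `O=C(Nc1cccc(-n2cc(-c3ccncc3)c(-c3ccc(Cl)c(O)c3)n2)c1)Nc1ccc(Cl)c(C(F)(F)F)c1`, is the next compound to be measured. It differs from compound 1 in one place: trifluoromethyl in place of chloro on an aromatic carbon. The change sits on the aromatic carbon ortho to a chloro group and meta to a large group, on the outer aryl of the shared core.

With no measured step of this kind in the series, the expectation for compound 4 is of a step from compound 1 that stays within or close to the scatter, with a slight lean toward a lower number, so that the step of a 1.4-fold lower number from compound 1 to compound 4 (0.13 log units; within the scatter) is expected to be small. Compound 4 is therefore estimated at 500 nM, with a range of 200 nM to 1400 nM.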

Compound 4, concentration for 50% growth inhibition: 376 nM
Compound 4: the middle estimate sits 1.3-fold (0.12 log units) above what was measured; measured number inside the range.
By their numbers in this assay, from the lowest: compounds 3, 4, 2 and 1 (each within the scatter of the next).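

In this assay, the change from 3,4-dichlorophenyl to 4-chloro-3-(trifluoromethyl)phenyl gives the series its first step in one place (a 1.8-fold lower number from compound 1 to compound 4 (0.26 log units; within the scatter)). This sets a first measured scale for a change at this aromatic carbon: trifluoromethyl, with 4 heavy atoms, stands in place of chloro, with 1 heavy atom, and the two cannot be told apart in this pair. Nothing shown accounts for the size of this step.

As far as these compounds go, what a nitrile, an amine or a carboxylic acid would give at this aromatic carbon remains open. Also open, from the compounds shown here alone, is whether the same step would hold if the chloro group ortho to this position were replaced by a methoxy group or a hydrogen.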